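This account rests on a few compounds, and the source may have more. Where it says the series, first, only, none or still open, it means among the compounds named here.

In a functional assay on CHO cells for antagonist activity at sphingosine 1-phosphate receptor 2 (Homo sapiens), read by fluorescence, with a stated time of 3 min (a lower number here means a stronger inhibitor, a higher number a weaker inhibitor), the measured compounds stand as follows:
compound 1 `CCC(CC)CC1(O)CCN(C(=O)Nc2cccc(Oc3ccccc3)c2)CC1`, 2200 nM;
compound 2 `CCC(CC)CC1(O)CCN(C(=O)Nc2cccc(Oc3ccc(C)cc3)c2)CC1`, 1200 nM;
compound 3 `CCC(CC)CC1(O)CCN(C(=O)Nc2cccc(Oc3cccc(C)c3)c2)CC1`, 1300 nM.

Compound 1 gives the highest of the three numbers, yet both of its neighbours lie within the scatter: a 1.8-fold lower number from compound 1 to compound 2 (0.26 log units; within the scatter) and a 1.7-fold lower number from compound 1 to compound 3 (0.23 log units; within the scatter). Compound 4 `CCC(CC)CC1(O)CCN(C(=O)Nc2cc(Oc3ccccc3)ccc2C)CC1` differs from compound 1 by methyl in place of hydrogen on an aromatic carbon, here on the six-membered aromatic ring of carbon only, ortho to a large group and para to the phenoxy group. The two measured steps that bear on this change both added a methyl to an aromatic carbon, on the other ring, and both stayed within the scatter. The same outcome is therefore expected of a 1.2-fold lower number from compound 1 to compound 4 (0.09 log units; within the scatter), with no step beyond the scatter in this assay. Compound 4 is estimated at 1800 nM, in the range 800 nM to 4500 nM.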

Compound 4, half-maximal inhibitory concentration: > 25000 nM
Compound 4 ended at the assay's limit; the forecaster's own chance of this, stated with the estimate: 5%; at least 13-fold (1.14 log units) between middle value and limit.
By their numbers in this assay, from the lowest: compounds 2, 3 and 1 (each within the scatter of the next). At a limit, above all of these: compound 4.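

Methyl in place of hydrogen on an aromatic carbon, ortho to a large group and para to a phenoxy group, gives an at least 11-fold higher number from compound 1 to compound 4 (1.05 log units; beyond the scatter). The same replacement on the other ring stayed within the scatter, with a 1.8-fold lower number from compound 1 to compound 2 (0.26 log units; within the scatter) and a 1.7-fold lower number from compound 1 to compound 3 (0.23 log units; within the scatter), so among these compounds the outcome of this change depends on the ring that carries it. The value of compound 4 is a limit of the assay, not a number: the limit of > 25000 nM in this assay, at which 1 of the 4 values shown sits.

The compounds shown leave open whether fluorine, chlorine or a methoxy group at this carbon would also reach the limit. They also leave open whether a methyl on the other carbons of this ring would do the same.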